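A few compounds are considered here, and "the series" means these few. Any claim that something is new, unique, unknown or untested is made for them only; others in the source may bear on it.

Measured compounds in a functional assay on MCF7 cells (Homo sapiens) for inhibition, read by sulforhodamine B assay, with a stated time of 24 h; a higher number here means a weaker inhibitor, a lower number a stronger inhibitor:

compound 1, `N#Cc1c(-c2ccccc2)cn(-c2ccc(S(=O)(=O)Nc3nccs3)cc2)c1N`: 3490 nM
compound 2, `O=c1[nH]cnc2c1c(-c1ccccc1)cn2-c1ccc(S(=O)(=O)Nc2nccs2)cc1`: 6210 nM
compound 3, `N#Cc1c(-c2ccccc2)cn(-c2ccc(S(=O)(=O)Nc3ccccn3)cc2)c1NC(=O)CCC(=O)O`: 8320 nM

Compound 1 carries the lowest number of the three in this assay. Compound 2 sits nearest to it, and the gap between compound 1 and compound 2 lies within the usual scatter of this kind of measurement, so the two cannot be placed in an order. Compound 3 stands furthest from compound 1, and that gap lies beyond the scatter; compound 3 also differs from compound 1 in more than one place, so nothing can be said about which of its changes carries that gap.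

Compound 4, `N#Cc1c(-c2ccccc2)cn(-c2ccc(S(=O)(=O)Nc3nccs3)cc2)c1N1C(=O)CCC1=O`, has not yet been measured in this assay. It is compound 1 with one change: 2,5-dioxopyrrolidin-1-yl in place of amino on an aromatic carbon. Within the data shown here, no pair of measured compounds differs in only that place, so no measured step can be read across to it. The nearest hint is compound 3, where the amino of compound 1 also carries an acyl group, and compound 3 gives 8320 nM in this assay; with its second change, that hint stays weak. The step is expected to be small, toward a higher number or none beyond the scatter. Compound 4 is estimated at 5200 nM in this assay, within 2000 nM to 13000 nM, which means an expected step of a 1.5-fold higher number from compound 1 to compound 4 (0.17 log units; within the scatter).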

Compound 4, half-maximal inhibitory concentration: 6710 nM
Estimate against measurement, compound 4: 1.3-fold (0.11 log units) below; the measured number falls inside the stated range.
By their numbers in this assay, from the lowest: compounds 1, 2, 4 and 3 (each within the scatter of the next, the first and the last beyond it).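

Among these compounds, this is the first single-place step at this position, on the aromatic carbon next to the ring nitrogen and next to the ring atom that bears the cyano group. In this assay, 2,5-dioxopyrrolidin-1-yl in place of amino gives a 1.9-fold higher number from compound 1 to compound 4 (0.28 log units; within the scatter), so compound 1 and compound 4 cannot be placed in an order, even though the entering group brings 7 heavy atoms and a five-membered non-aromatic ring for the 1 heavy atom of amino, and no hydrogen-bond donor for the 1 of amino. Nothing measured on these compounds bears on the reason for this result.

The step does not separate the ring from the two carbonyls: an open acetylamino group would keep a carbonyl without the ring, and pyrrolidin-1-yl would keep the ring without the carbonyls. As far as these compounds go, the step also rests on a single background, the core of compound 1, so it remains open whether the same exchange on a longer chain, such as butanoylamino, or with a free carboxylic acid at the chain end, would stay within the scatter of compound 1.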